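Linear chain in place of branched acid on sulfur

This account rests on a few compounds, and the source may have more. Where it says the series, first, only, none or still open, it means among the compounds named here.

Compound 1 `CC(C)(Sc1ccncc1Oc1ccc(C#N)c2ccccc12)C(=O)O` gives 5210 nM in an assay on HEK293 cells for inhibition of solute carrier family 22 member 12 (Homo sapiens), read by scintillation counting, with stated times of 30 min and 15 min (on this read-out higher numbers stand for weaker inhibition and lower numbers for stronger inhibition), the highest of the two numbers in hand; compound 2 `N#Cc1ccc(Nc2cnccc2SCCCCC(=O)O)c2ccccc12` gives 2280 nM in this assay, a difference beyond the scatter. Compound 3 `N#Cc1ccc(Oc2cnccc2SCCCC(=O)O)c2ccccc12` keeps the atoms of compound 1 but joins them differently: 3-carboxypropyl in place of 1-carboxy-1-methylethyl on a sulfur. For the measured compounds named here, no measured pair isolates this change, so the direction is uncertain; a modest move toward a lower number is expected, a 2.0-fold lower number from compound 1 to compound 3 (0.30 log units; within the scatter), with compound 2 as the only hint that an unbranched chain can sit lower. Compound 3 is therefore estimated at 2600 nM, with a range of 900 nM to 7500 nM.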

Compound 3, half-maximal inhibitory concentration: 1230 nM
For compound 3 the middle estimate is 2.1-fold (0.33 log units) above the measured one; low and high end bracket the measured number.
By their numbers in this assay, from the lowest: compounds 3 and 2 (each within the scatter of the next); then compound 1.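

In this assay the step to 3-carboxypropyl on a sulfur is a 4.2-fold lower number from compound 1 to compound 3 (0.63 log units; beyond the scatter) and lies beyond the scatter. For the compounds shown here, this is the first pair to isolate the change: with the same atoms joined differently, the unbranched chain gives the lower number, so the arrangement of the acid chain at this position matters, not only its composition. Nothing available accounts for the step.

Still open, as far as these compounds go, is how a shorter chain such as carboxymethyl, or an amide in place of the carboxylic acid, would read at this sulfur. Compound 2 differs from compound 3 in more than one place, so it cannot separate chain length from the link to the core.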